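The compounds below may be only part of what the source reports. "The series", "measured", "known", "first", "only" and "open" are said of these compounds alone.

Working notes on the sulfated sugar series.

Two members have been measured in an assay on isolated protein for binding affinity to vascular endothelial growth factor A, long form (Homo sapiens), read by surface plasmon resonance; on this read-out higher numbers stand for weaker binding and lower numbers for tighter binding. Compound 1 `CO[C@H]1O[C@H](CNC(=O)CN(Cc2ccccc2)C(C)=O)[C@@H](OS(=O)(=O)O)[C@H](OS(=O)(=O)O)[C@@H]1OS(=O)(=O)O` gives 77000 nM in this assay. Compound 2 `CCN(CC(=O)NC[C@H]1O[C@H](OC)[C@@H](OS(=O)(=O)O)[C@@H](OS(=O)(=O)O)[C@@H]1OS(=O)(=O)O)C(=O)CCCCCCCCCOS(=O)(=O)O` differs from compound 1 in several places at once. In this assay compound 2 gives 545000 nM. Of the two numbers recorded, compound 1 stands lowest, and the gap to compound 2 lies beyond the usual scatter of repeated measurements; since the two differ in more than one place, nothing is read into which part of the change carries that gap.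

Compound 3 `CO[C@H]1O[C@H](CNC(=O)CN(C(C)=O)C2CCCCC2)[C@@H](OS(=O)(=O)O)[C@H](OS(=O)(=O)O)[C@@H]1OS(=O)(=O)O` is not yet measured. It differs from compound 1 by a single change, cyclohexyl in place of benzyl on an amide-type nitrogen. Within the data shown here, no measured pair in the set isolates this change, so there is no step to read it against. The expected outcome is a step from compound 1 to compound 3 of a 1.3-fold higher number from compound 1 to compound 3 (0.11 log units; within the scatter) in this assay, that is, no shift beyond the scatter in either direction. Compound 3 is therefore estimated at 100000 nM in this assay, with a range from 40000 nM to 250000 nM.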

Compound 3, dissociation constant: 1700000 nM
For compound 3 the middle estimate is 17-fold (1.23 log units) below the measured one; the whole stated range lies below it.
By their numbers in this assay, from the lowest: compound 1; then compound 2; then compound 3.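

The exchange of benzyl for cyclohexyl on the amide-type nitrogen gives a 22-fold higher number from compound 1 to compound 3 (1.34 log units; beyond the scatter) in this assay, so this position responds strongly to the group it carries. Compound 1 and compound 2 could not show this, as they differ in several places at once. The change is small by count, with 7 heavy atoms leaving and 6 entering, a six-membered aromatic ring giving way to a six-membered non-aromatic one, and no hydrogen-bond donors, acceptors or net charge on either group, yet nothing at hand says what lies behind a step of this size.

The ring type and the extra carbon of benzyl change together here, so the step cannot yet be assigned to either; phenyl or cyclohexylmethyl on the same nitrogen would separate the two. Also open, on these data alone, is how far the position tolerates other groups, such as a pyridylmethyl or a benzyl carrying a carboxylic acid, and whether the step holds with a group other than acetyl on that nitrogen.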